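Carboxylic acid to tetrazole on the cyclohexyl amide

The source may report more compounds than this note shows. Statements on the series, on what has been measured and on what is new or still open speak of the compounds shown alone.

Going by the values given here, compound 1 `C[C@]1(C(=O)O)CC[C@H](C(=O)N2CC[C@](c3ccc(C(F)(C(F)(F)F)C(F)(F)F)cc3)(S(=O)(=O)c3ccc(F)cc3)C2)CC1` stands highest of the two numbers so far in an ADME assay on microsomes from liver (Mus musculus) for metabolic stability, with a stated time of 10 min (a lower number here means that less of the compound is left, a higher number that more of the compound is left), where compound 1 gives 93%. Among the compounds with values here, compound 2 `O=C(O)C12CCC(C(=O)N3CC[C@](c4ccc(C(F)(C(F)(F)F)C(F)(F)F)cc4)(S(=O)(=O)c4ccc(F)cc4)C3)(CC1)CC2` gives 73% in this assay, and the step of a number 20 percentage points lower from compound 1 to compound 2 (beyond the scatter) is the only measured step. Compound 3 `O=C(N1CC[C@](c2ccc(C(F)(C(F)(F)F)C(F)(F)F)cc2)(S(=O)(=O)c2ccc(F)cc2)C1)C12CCC(C(=O)O)(CC1)OC2` has no result in this assay; for compound 3 the entry reads "not determined" (no result reported).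

Compound 4 `O=C([C@H]1CC[C@H](c2nnn[nH]2)CC1)N1CC[C@](c2ccc(C(F)(C(F)(F)F)C(F)(F)F)cc2)(S(=O)(=O)c2ccc(F)cc2)C1` differs from compound 1 in this way: 4-(1H-tetrazol-5-yl)cyclohexyl in place of 4-carboxy-4-methylcyclohexyl on a carbonyl carbon. Within the data shown here, no measured step bears directly on this change: the step of a number 20 percentage points lower from compound 1 to compound 2 (beyond the scatter) concerns an exchange of the saturated ring system on the carbonyl carbon and leaves the carboxy group in place, so it says nothing about the tetrazole. Compound 1 already sits near the top of the scale in this assay, which leaves little room upward. The expected step of a number 8 percentage points lower from compound 1 to compound 4 (within the scatter) is therefore none beyond the scatter, with a lean downward only because compound 1 sits at 93%. Compound 4 is estimated at 85%, within 65% to 98%.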

Compound 4, percent of the compound remaining: 73%
Compound 4: middle estimate off by 12 percentage points, on the high side; measured number inside the range.
By their numbers in this assay, from the lowest: compounds 2 and 4 (each within the scatter of the next); then compound 1.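

In this assay the swap of 4-carboxy-4-methylcyclohexyl for 4-(1H-tetrazol-5-yl)cyclohexyl on the carbonyl carbon gives a number 20 percentage points lower from compound 1 to compound 4 (beyond the scatter) and shows that this position can carry a group with no carboxy function and still leave a reading level with the bridged acid, as no change at the digits printed from compound 2 to compound 4 (within the scatter) confirms. So both replacements of the group in compound 1 read lower, and neither of the two can be placed ahead of the other. Nothing available here accounts for the loss in either case.

Going by these compounds, the change to compound 4 replaces the carboxy group and removes the methyl group at once, so the share of each remains open. A 4-carboxycyclohexyl group, or a 4-methyl-4-(1H-tetrazol-5-yl)cyclohexyl group, on the same carbonyl carbon would separate the two.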